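The compounds below may be only part of what the source reports. "The series", "measured", "known", "first", "only" and "open" are said of these compounds alone.

In a functional assay on K562 cells (Homo sapiens) for antiproliferative activity, with a stated time of 72 h (a lower number here means a stronger inhibitor, a higher number a weaker inhibitor), compound 1 `OC[C@H]1O[C@@H](n2cnc3c(NCc4ccc(F)cc4)ncnc32)[C@H](O)[C@@H]1O` gives 2700 nM. Compound 2 `Cc1cccc(CNc2ncnc3c2ncn3[C@@H]2O[C@H](CO)[C@@H](O)[C@H]2O)c1` reaches only the limit of > 166000 nM in this assay. Compound 3 `COc1cccc(CNc2ncnc3c2ncn3[C@@H]2O[C@H](CO)[C@@H](O)[C@H]2O)c1OC` likewise stops at the limit of > 166000 nM in this assay. Compound 2 thus stands at the limit of > 166000 nM in this assay, at which 2 of the 3 values shown sit. Within the data shown here, the steps from the one numbered value are an at least 61-fold higher number from compound 1 to compound 2 (1.78 log units; beyond the scatter) and an at least 61-fold higher number from compound 1 to compound 3 (1.78 log units; beyond the scatter), while the pair at the limit gives a step that the two limits leave unreadable from compound 2 to compound 3. Compound 4 `COc1cccc(CNc2ncnc3c2ncn3[C@@H]2O[C@H](CO)[C@@H](O)[C@H]2O)c1O` differs from compound 2 by 2-hydroxy-3-methoxyphenyl in place of 3-methylphenyl on a saturated chain carbon bound to a nitrogen on an aromatic ring. Compound 4 is expected to stay near the limit in this assay because a step that the two limits leave unreadable from compound 2 to compound 3 left no readable difference between compound 2 and compound 3 despite a comparable change in the same place. Compound 4 is therefore estimated at 150000 nM, within 30000 nM to 500000 nM. This expected outcome corresponds to an at least 1.1-fold lower number from compound 2 to compound 4 (0.04 log units; that floor lies within the scatter).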

Compound 4, half-maximal inhibitory concentration: 27900 nM
The estimate for compound 4 lay 5.4-fold (0.73 log units) above the measured number; measured number outside the range, below it.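

Among these compounds, on the saturated chain carbon bound to a nitrogen on an aromatic ring, the aryl group can lift activity off the limit: the data show an at least 5.9-fold lower number from compound 2 to compound 4 (0.77 log units; beyond the scatter), and an at least 5.9-fold lower number from compound 3 to compound 4 (0.77 log units; beyond the scatter), where the only change is hydrogen in place of methyl on an oxygen on an aromatic ring. Both steps are floors, as each starts from a limit: the limit of > 166000 nM in this assay, at which 2 of the 4 values shown sit. The 2-hydroxy-3-methoxyphenyl group still falls short of 4-fluorophenyl, with a 10-fold higher number from compound 1 to compound 4 (1.01 log units; beyond the scatter).

As far as these compounds go, whether the gain needs the methoxy group alongside the hydroxy group stays open. So does whether an amine or a carboxylic acid in the hydroxy group's place would keep it.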